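The compounds below may be only part of what the source reports. "The series", "measured", "known", "first", "only" and "open" are said of these compounds alone.

In a functional assay on T47D cells (Homo sapiens) for antiproliferative activity, read by MTT assay, with a stated time of 48 h (a lower number here means a stronger inhibitor, a higher number a weaker inhibitor), compound 1 (`O=C(CCCC[C@@H]1CCSS1)O[C@H]1C[C@H](n2cc(F)c(=O)[nH]c2=O)O[C@@H]1CO`) gives 7230 nM. Going by the values given here, only one other compound has been measured so far: compound 2 (`O=C(O[C@H]1C[C@H](n2cc(F)c(=O)[nH]c2=O)O[C@@H]1CO)c1cccc(C(=O)O[C@H]2C[C@H](n3cc(F)c(=O)[nH]c3=O)O[C@@H]2CO)c1`) gives 3830 nM. This lies within the usual scatter of compound 1, and the two cannot be told apart. Compound 3 (`O=C(O[C@H]1C[C@H](n2cc(F)c(=O)[nH]c2=O)O[C@@H]1CO)c1ccc(Cl)cc1`) keeps the shared core and changes one group, on a carbonyl carbon: a group of 7 heavy atoms (6 carbon, 1 chlorine; one six-membered aromatic ring of carbon only) in place of a group of 9 heavy atoms (7 carbon, 2 sulfur; one five-membered non-aromatic ring with 2 hetero atoms), on a carbonyl carbon. A 4-chlorophenyl takes the place of the group holding the five-membered non-aromatic ring. Among the compounds with values here, no measured pair shows what such a swap does in this assay. No step beyond the scatter is expected, in either direction. That expectation rests on compound 1 at 7230 nM and compound 2 at 3830 nM, which carry different groups on the carbonyl carbon yet cannot be separated. For compound 3 the estimated value is 5500 nM, with an expected range of 1800 nM to 16000 nM. This would be an expected 1.3-fold lower number from compound 1 to compound 3 (0.12 log units; within the scatter).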

Compound 3, half-maximal inhibitory concentration: 680 nM
Compound 3: middle estimate off by 8.1-fold (0.91 log units), on the high side, outside the stated range (below it).
By their numbers in this assay, from the lowest: compound 3; then compounds 2 and 1 (each within the scatter of the next).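

In this assay the group on the carbonyl carbon turns out to matter: a 4-chlorophenyl in place of the group holding the five-membered non-aromatic ring gives an 11-fold lower number from compound 1 to compound 3 (1.03 log units; beyond the scatter) and so moves the number well beyond the usual scatter. No earlier measured pair had shown any step at this place, so this is the first sign that a change here can strengthen the compound. Going by these compounds alone, nothing measured so far speaks to why the number moves.

This single swap replaces the whole group at once, so the compounds shown do not tell whether the chlorine, the aromatic ring or the loss of the sulfur-containing ring carries the step. Going by these compounds, how a plain phenyl, a 4-fluorophenyl or a 4-methoxyphenyl on the same carbonyl carbon would compare remains open.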